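This account rests on a few compounds, and the source may have more. Where it says the series, first, only, none or still open, it means among the compounds named here.

Working notes on the aryl ketone series sharing the core of compound 1 `COc1cccc(C(=O)CC2C(C#N)=C(N)Oc3ccc(Br)cc32)c1`. In an ADME assay on MCF-10A cells (Homo sapiens) for cytotoxicity, read by sulforhodamine B assay, with a stated time of 72 h, tested at 10 uM (a higher number here means a stronger effect of the compound at the concentration tested, a lower number a weaker effect), compound 1 gives 101%. Compound 2 `Cc1ccc(C(=O)CC2C(C#N)=C(N)Oc3ccc(Cl)cc32)cc1` in this assay gives 41.8%, and compound 3 `N#CC1=C(N)Oc2ccc(Br)cc2C1CC(=O)c1ccc(Br)cc1` gives 32.6%. Compound 3 stands lowest of the three numbers, but compound 2 lies within the scatter of it, so no order between the two is claimed; only compound 1 is clearly apart, through the step of a number 68.4 percentage points lower from compound 1 to compound 3 (beyond the scatter), 4-bromophenyl in place of 3-methoxyphenyl on a carbonyl carbon.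

The next compound, compound 4 `Cc1ccc(C(=O)CC2C(C#N)=C(N)Oc3ccc(Br)cc32)cc1`, differs from compound 3 by methyl in place of bromo on an aromatic carbon. Among the compounds with values here, no measured step covers this exact exchange. Within the data shown here, the one measured step, from compound 1 to compound 3, concerns a different part of the aryl group and was large; it does not transfer. Compound 2 carries the same 4-methylphenyl as compound 4, on a core with chloro instead of bromo, and sits within the scatter of compound 3. The step is therefore expected to be a number 7.4 percentage points higher from compound 3 to compound 4 (within the scatter), within the scatter. Compound 4 is estimated at 40%, in the range 20% to 65%.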

Compound 4, a percentage reported as activity, at one concentration (the size of the read-out at that concentration, not a potency): 133%
The estimate for compound 4 lay 93 percentage points below the measured number; the measured number lies above the stated range.
By their numbers in this assay, from the lowest: compounds 3 and 2 (each within the scatter of the next); then compound 1; then compound 4.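

In this assay, the exchange at the far end of the aryl ketone is no small change: a number 100.4 percentage points higher from compound 3 to compound 4 (beyond the scatter) is the result of methyl in place of bromo on the aromatic carbon alone. With 4-methylphenyl held constant, bromo in place of chloro on the shared core gives a number 91.2 percentage points higher from compound 2 to compound 4 (beyond the scatter) as its step, so the closeness of compound 2 and compound 3 did not mean that either place is silent. Starting from compound 1, 4-methylphenyl gives a number 32 percentage points higher from compound 1 to compound 4 (beyond the scatter) as its step, the opposite direction to a number 68.4 percentage points lower from compound 1 to compound 3 (beyond the scatter) for 4-bromophenyl, so the outcome of replacing 3-methoxyphenyl depends on the group entering.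

Going by these compounds, how an amine, a carboxylic acid or a longer chain in place of methyl would read on this aryl group remains open. Nothing available accounts for the size of these steps.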